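The source may report more compounds than this note shows. Statements on the series, on what has been measured and on what is new or still open speak of the compounds shown alone.

Compound 1 `O=c1[nH]c(=O)n([C@H]2C[C@H](O)[C@@H](CO)O2)cc1/C=N/O` gives 15500 nM in an ADME assay on L1210/0 cells (Mus musculus) for cytotoxicity, with a stated time of 48 h; a lower number here means a stronger inhibitor, a higher number a weaker inhibitor.
Compound 2 `O=c1[nH]c(=O)n([C@H]2C[C@H](O)[C@@H](CO)O2)cc1/C=C/Cl` gives > 200000 nM, which is a limit of the assay and not a number.

In this assay compound 2 therefore sits at the limit of > 200000 nM in this assay, at which 1 of the 2 values shown sits, the weaker end of what was measured. Among the compounds with values here, the only step known here is an at least 12-fold higher number from compound 1 to compound 2 (1.11 log units; beyond the scatter), a change on the same aromatic carbon, and it bears on the new change only loosely. Compound 3 `CCCCCC#Cc1cn([C@H]2C[C@H](O)[C@@H](CO)O2)c(=O)[nH]c1=O` differs from compound 2 by hept-1-yn-1-yl in place of 2-chloroethenyl on an aromatic carbon. Within the data shown here, no measured step covers this replacement, so the expectation rests on compound 2 alone and stays wide. Compound 3 is estimated at 100000 nM in this assay, between 20000 nM and 300000 nM, which would mean an at least 2.0-fold lower number from compound 2 to compound 3 (0.30 log units; that floor lies within the scatter), a step expected with uncertain direction.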

Compound 3, half-maximal inhibitory concentration: > 200000 nM
Compound 3 ended at the assay's limit (the forecaster's own chance of this, stated with the estimate: 50%); middle value at least 2.0-fold (0.30 log units) away from the limit.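

In this assay compound 3 also gives a limit and not a number: the limit of > 200000 nM in this assay, at which 2 of the 3 values shown sit. Hept-1-yn-1-yl on this aromatic carbon produces an at least 12-fold higher number from compound 1 to compound 3 (1.11 log units; beyond the scatter), so a second, longer group with no ring also ends at that limit. The step between the two limits cannot be read, so hept-1-yn-1-yl and 2-chloroethenyl cannot be ranked against each other here. As far as these compounds go, whether a shorter alkynyl chain, an amine or a carboxylic acid at this position would give a readable value stays open. From the compounds shown here alone, how far compound 2 and compound 3 actually lie beyond the limit also stays open.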